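The compounds below may be only part of what the source reports. "The series", "measured", "known", "first", "only" and "open" are said of these compounds alone.

Of the compounds shown here, three of one shared core have so far been tested in a functional assay on the whole organism (strain Wistar albino) for inhibition, with Rattus norvegicus as the target, read by paw edema, with stated times of 1 h and 4 h, at a dose of 40 mg/kg by the oral route; on this read-out lower numbers stand for less inhibition and higher numbers for more inhibition at the one dose given (going by the name of the read-out). Compound 1 `Cc1nc(-c2ccc(Cl)cc2)sc1C1SCC(=O)N1c1ccc(F)c(Cl)c1` gives 65.1% in this assay, compound 2 `COc1ccc(N2C(=O)CSC2c2sc(-c3ccccc3)nc2C)cc1` gives 67.1%, and compound 3 `Cc1nc(-c2ccc(Cl)cc2)sc1C1SCC(=O)N1c1ccc(Cl)cc1` gives 43.2%, the lowest of the three numbers, with both other values beyond the scatter above it. Within the data shown here, the only single-site step measured so far, a number 21.9 percentage points lower from compound 1 to compound 3 (beyond the scatter), changes the aryl group on the amide-type nitrogen; it does not involve a methoxy group, so no measured step speaks directly to the change at hand.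

Compound 4 `COc1ccc(N2C(=O)CSC2c2sc(-c3ccc(Cl)cc3)nc2C)cc1` differs from compound 3 by methoxy in place of chloro on an aromatic carbon. Compound 3 gives 43.2%. The methoxy on the ring bound to that nitrogen also appears in compound 2, though with a second difference elsewhere, and compound 2 gives 67.1%. On that basis compound 4 is expected to move upward, with an estimated step of a number 18.8 percentage points higher from compound 3 to compound 4 (beyond the scatter). The estimate for compound 4 in this assay is 62%, within a range from 48% to 76%.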

Compound 4, a percentage reported as inhibition, in the whole organism at one dose (the size of the read-out at that dose, not a potency): 59.1%
Estimate against measurement, compound 4: 2.9 percentage points above; measured number inside the range.
By their numbers in this assay, from the lowest: compound 3; then compounds 4, 1 and 2 (each within the scatter of the next).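

In this assay the change from 4-chlorophenyl to 4-methoxyphenyl, on the aromatic carbon para to a large group, gives a number 15.9 percentage points higher from compound 3 to compound 4 (beyond the scatter) with nothing else in the molecule altered, whereas the earlier methoxy compound, compound 2, carried a second difference. Chloro in place of hydrogen on an aromatic carbon gives a number 8 percentage points lower from compound 2 to compound 4 (within the scatter) and 4-methoxyphenyl in place of 3-chloro-4-fluorophenyl on the amide-type nitrogen gives a number 6 percentage points lower from compound 1 to compound 4 (within the scatter) and so neither of these two changes separates the compounds it links. No supporting measurement is available to explain the rise from chloro to methoxy.

The compounds shown leave open whether the gain is particular to methoxy or would also appear with a hydroxyl, an amine or a longer ether chain at this position. Among these compounds, the chloro-to-methoxy change is also read in only one pair, so its size with other groups elsewhere on the shared core remains unknown.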